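A few compounds are considered here, and "the series" means these few. Any claim that something is new, unique, unknown or untested is made for them only; others in the source may bear on it.

Going by the values given here, in a physicochemical assay for solubility, read by nephelometry, measured as kinetic solubility, at pH 2.0 (on this read-out higher numbers stand for higher solubility and lower numbers for lower solubility), compound 1 `CC(C)(C)c1cc(C(=O)Nc2nc(CNS(C)(=O)=O)cs2)n(Cc2ccccc2)n1` gives 3.1 ug/mL, the only actual number in this small set. Compound 2 `NCc1csc(NC(=O)c2ccn[nH]2)n1` reads > 100 ug/mL, which is a limit of the assay. Compound 3 `Cn1nc(C(C)(C)C)cc1C(=O)Nc1nc(CN)cs1` reads > 100 ug/mL, also a limit. Compound 4 `Cc1csc(NC(=O)c2cc(C(C)(C)C)nn2Cc2ccccc2)n1` is the next to be read, and the change is hydrogen in place of methanesulfonamido on a saturated chain carbon bound to an aromatic carbon, so that (methanesulfonamido)methyl becomes methyl. Among the compounds with values here, no measured pair isolates this change, so the expectation rests on compound 1 alone. The estimated step of a 1.2-fold lower number from compound 1 to compound 4 (0.09 log units; within the scatter) in this assay is expected to stay within the scatter. For compound 4 the expected value is 2.5 ug/mL, with an estimated range of 0.8 ug/mL to 8 ug/mL.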

Compound 4, solubility: < 1.6 ug/mL
Compound 4: no number, only a limit; the forecaster's own chance of this, stated with the estimate: 15%; at least 1.5-fold (0.19 log units) between middle value and limit.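

In this assay compound 4 gives < 1.6 ug/mL, which is a limit and not a number. Hydrogen in place of methanesulfonamido on a saturated chain carbon bound to an aromatic carbon gives an at least 1.9-fold lower number from compound 1 to compound 4 (0.28 log units; that floor lies within the scatter), so this change at this position has a floor but no measured size. Compound 4 is the first compound here to reach the low limit of the read-out: the limit of < 1.6 ug/mL in this assay, at which 1 of the 4 values shown sits.

From the compounds shown here alone, the true size of the step remains open. So does how a carboxylic acid at this position on the core of compound 1 would read in this assay.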